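The source may report more compounds than this note shows. Statements on the series, on what has been measured and on what is new or still open speak of the compounds shown alone.

Three compounds share one core and differ only in the side chain and in the halogenated ring hanging from the urea. In a functional assay on HT-29 cells (Homo sapiens) for cytotoxicity, read by MTT assay, with a stated time of 72 h (a lower number here means a stronger inhibitor, a higher number a weaker inhibitor), compound 1 `CN(C)CCNc1nc(-c2ccc(NC(=O)Nc3ccc(Cl)cc3)cc2)nc2ccsc12` gives 95 nM. Compound 2 `CCN(CC)CCCNc1nc(-c2ccc(NC(=O)Nc3ccc(F)cc3)cc2)nc2ccsc12` gives 340 nM, and compound 3 `CCN(CC)CCCNc1nc(-c2ccc(NC(=O)Nc3ccccc3F)cc2)nc2ccsc12` gives 550 nM, the highest of the three numbers; the step of a 1.6-fold higher number from compound 2 to compound 3 (0.21 log units; within the scatter) is within the scatter, while the gap from compound 3 to compound 1 lies beyond it. Compound 4 `CCN(CC)CCCNc1nc(-c2ccc(NC(=O)Nc3ccc(Cl)cc3)cc2)nc2ccsc12` differs from compound 3 by 4-chlorophenyl in place of 2-fluorophenyl on an amide-type nitrogen. Within the data shown here, only the step from compound 2 to compound 3 concerns the ring alone, and it was small; compound 1 and compound 2 differ in two places, so their values show only that a 4-chlorophenyl can go with a lower number. Compound 4 is therefore expected to give 200 nM, within 70 nM to 600 nM, an estimated step of a 2.8-fold lower number from compound 3 to compound 4 (0.44 log units; beyond the scatter).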

Compound 4, half-maximal inhibitory concentration: 58 nM
Compound 4: the middle estimate sits 3.4-fold (0.54 log units) above what was measured; measured number outside the range, below it.
By their numbers in this assay, from the lowest: compounds 4 and 1 (each within the scatter of the next); then compounds 2 and 3 (each within the scatter of the next).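

Chloro in place of fluoro on an aromatic carbon, with the side chain unchanged, gives a 5.9-fold lower number from compound 2 to compound 4 (0.77 log units; beyond the scatter) and so shows that the halogen on this ring can move the number beyond the scatter. The change from 2-fluorophenyl to 4-chlorophenyl gives a 9.5-fold lower number from compound 3 to compound 4 (0.98 log units; beyond the scatter) whereas the side-chain change gives only a 1.6-fold lower number from compound 1 to compound 4 (0.21 log units; within the scatter) and so does not tell those two side chains apart. No measurement at hand explains why chloro and fluoro differ here.

Still open, as far as these compounds go, is whether bromo or methyl in place of chloro would keep the number this low. A 2-chlorophenyl would help separate the identity of the halogen from its place on the ring.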